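Halogen exchange on the aromatic carbon: towards compound 4

The source may hold more compounds than are shown below. What is called first, only, known or untested is meant among the compounds shown, and "the series" means these compounds.

Compound 3 `O=C(NCc1ccc(NC(=O)c2cc(Br)ccc2N2CCCC2)cc1)OCc1cccnc1` gives > 100000 nM in a functional assay on SGC-7901 cells (Homo sapiens) for inhibition, read by MTT assay, with a stated time of 72 h (on this read-out higher numbers stand for weaker inhibition and lower numbers for stronger inhibition), which is a limit of the assay and not a number. Compound 1 `O=C(NCc1ccc(NC(=O)c2cc(Cl)ccc2N2CCCC2)cc1)OCc1cccnc1` likewise gives only the limit > 100000 nM in this assay. For the measured compounds named here, compound 2 `Cc1ccc(N2CCCC2)c(C(=O)Nc2ccc(CNC(=O)OCc3cccnc3)cc2)c1` gives 65300 nM in this assay, the sole value that is a number. Going by the values given here, the steps of an at least 1.5-fold lower number from compound 1 to compound 2 (0.18 log units; that floor lies within the scatter) and an at least 1.5-fold higher number from compound 2 to compound 3 (0.18 log units; that floor lies within the scatter) are floors set by the limit of > 100000 nM in this assay, at which 2 of the 3 values shown sit, and the halogen swap a step that the two limits leave unreadable from compound 1 to compound 3 is the nearest precedent. Compound 4 `O=C(NCc1ccc(NC(=O)c2cc(F)ccc2N2CCCC2)cc1)OCc1cccnc1` differs from compound 3 by fluoro in place of bromo on an aromatic carbon. With both halogen analogues at the limit, no step beyond the scatter is expected. Compound 4 is estimated at 100000 nM, with a range of 50000 nM to 300000 nM. The step of a number no higher from compound 3 to compound 4 (the limit leaves the size open) is expected to stay within the scatter.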

Compound 4, half-maximal inhibitory concentration: 44800 nM
For compound 4 the middle estimate is 2.2-fold (0.35 log units) above the measured one; the whole stated range lies above it.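

Fluoro is the only halogen here that gives a number instead of a limit on this aromatic carbon, para to a pyrrolidin-1-yl group, with an at least 2.2-fold lower number from compound 3 to compound 4 (0.34 log units; beyond the scatter) and an at least 2.2-fold lower number from compound 1 to compound 4 (0.34 log units; beyond the scatter). Fluoro and methyl cannot be ordered at this position, with a 1.5-fold lower number from compound 2 to compound 4 (0.16 log units; within the scatter). The two halogen steps are floors and not sizes: the limit of > 100000 nM in this assay, at which 2 of the 4 values shown sit.

As far as these compounds go, the true distance from compound 4 to the chloro and bromo compounds stays open. Also open, from the compounds shown here alone, is whether an amine, a hydroxyl or a carboxylic acid on this carbon would give a number clearly apart from compound 4.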